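From Cyclopropyl to Chloro on the Aromatic Ring

A few compounds are considered here, and "the series" means these few. Any claim that something is new, unique, unknown or untested is made for them only; others in the source may bear on it.

Of the compounds shown here, two have been measured so far. Compound 1 `C[C@H](NCc1ccc(OCc2cccc(F)c2)cc1C1CC1)C(N)=O` gives 1660 nM in an assay on Sf9 cells for inhibition of Amine oxidase [flavin-containing] B (Homo sapiens), with stated times of 15 min and 60 min (on this read-out higher numbers stand for weaker inhibition and lower numbers for stronger inhibition), and compound 2 `CC1(C)C[C@@H](C(N)=O)N(Cc2ccc(OCc3cccc(F)c3)cc2F)C1` gives 6350 nM in this assay. Of these two numbers, compound 1 holds the lower one, and the gap to compound 2 lies beyond the usual scatter of this kind of measurement. Compound 2 differs from compound 1 in more than one place, so nothing is told here about which of its differences carries that gap.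

Compound 3 `C[C@H](NCc1ccc(OCc2cccc(F)c2)cc1Cl)C(N)=O` has not yet been measured. It differs from compound 1 in a single place, (chloro in place of cyclopropyl on an aromatic carbon). Going by the values given here, no step between measured compounds that differ in one place is available to lean on, so there is no measured precedent for this exchange. In the absence of such a reference, the step from compound 1 to compound 3 is expected to be small, a 1.1-fold lower number from compound 1 to compound 3 (0.04 log units; within the scatter), not clearly beyond the scatter in either direction. Compound 3 is therefore estimated at 1500 nM in this assay, with a range from 500 nM to 5000 nM.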

Compound 3, half-maximal inhibitory concentration: 28 nM
Beside the measured number, compound 3's estimate is 54-fold (1.73 log units) above it; measured number outside the range, below it.
By their numbers in this assay, from the lowest: compound 3; then compound 1; then compound 2.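

In this assay, putting chloro in place of cyclopropyl on the aromatic carbon ortho to the ((1-carbamoylethyl)amino)methyl group gives a 59-fold lower number from compound 1 to compound 3 (1.77 log units; beyond the scatter), a large step beyond the scatter. The earlier gap between compound 1 and compound 2 could not be tied to any one place, whereas here everything else in compound 1 stays the same, so the whole step belongs to this single position and shows that the read-out depends strongly on what this aromatic carbon carries. The cyclopropyl that leaves and the chloro that enters both count no hydrogen-bond donors or acceptors and no net charge, and nothing available here accounts for the size of the step.

From the compounds shown here alone, with only these two groups compared at this position on the shared core, it remains open how bromo, methyl or methoxy on the same carbon would compare with chloro and cyclopropyl. Going by these compounds, it also remains open whether chloro would bring a step of similar size on the core of compound 2, which differs from compound 1 in more than one place.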